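Phenyl in place of furan-3-yl: expected effect

The compounds below may be only part of what the source reports. "The series", "measured", "known", "first", "only" and "open" are said of these compounds alone.

Measured in a functional assay on THP-1 cells (Homo sapiens) for inhibition, read by ELISA, with stated times of 1 h and 18 h; a lower number here means a stronger inhibitor, a higher number a weaker inhibitor:
- compound 1 `NC(=O)[C@@H]1[C@H](Nc2nc(Nc3cccc(C(=O)N4CCCC4)c3)ncc2-c2cccnc2)[C@H]2C=C[C@@H]1C2`: 320 nM
- compound 2 `NC(=O)[C@@H]1[C@H](Nc2nc(Nc3cccc(C(=O)N4CCCC4)c3)ncc2-c2ccoc2)[C@H]2C=C[C@@H]1C2`: 40 nM

Compound 2 holds the lower of the two numbers, at 40 nM. The next compound is compound 3 `NC(=O)[C@@H]1[C@H](Nc2nc(Nc3cccc(C(=O)N4CCCC4)c3)ncc2-c2ccccc2)[C@H]2C=C[C@@H]1C2`, with the change (phenyl in place of furan-3-yl on an aromatic carbon), phenyl in place of furan-3-yl on an aromatic carbon. Among the compounds with values here, one measured step bears on this place: an 8.0-fold lower number from compound 1 to compound 2 (0.90 log units; beyond the scatter), with furan-3-yl in place of pyridin-3-yl. Within the data shown here, no phenyl compound has been measured, so this is weak guidance. A move to a higher number in this assay is expected, smaller than that step. The expected step is a 2.3-fold higher number from compound 2 to compound 3 (0.35 log units; beyond the scatter). For compound 3 the estimate is 90 nM, with an expected range of 30 nM to 270 nM.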

Compound 3, half-maximal inhibitory concentration: 220 nM
Beside the measured number, compound 3's estimate is 2.4-fold (0.39 log units) below it; the measured number falls inside the stated range.
By their numbers in this assay, from the lowest: compound 2; then compounds 3 and 1 (each within the scatter of the next).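

Within this assay, phenyl in place of furan-3-yl on the aromatic carbon gives a 5.5-fold higher number from compound 2 to compound 3 (0.74 log units; beyond the scatter), so a carbon-only six-membered ring does not keep the number of the five-membered furan. Phenyl in place of pyridin-3-yl gives a 1.5-fold lower number from compound 1 to compound 3 (0.16 log units; within the scatter), leaving the two six-membered rings unseparated and furan-3-yl alone apart from both. Nothing available explains this difference.

Open, on these data alone, is whether the lower number is specific to furan-3-yl. Furan-2-yl, thiophen-3-yl or a saturated ring such as cyclopentyl at this place would test that.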